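Pyridinone series: swapping the chlorophenyl arm for isobutyl

The source may hold more compounds than are shown below. What is called first, only, known or untested is meant among the compounds shown, and "the series" means these compounds.

compound 1 `Cc1cc(NCc2ccc(Cl)cc2)cc(=O)n1CCC(C)C` — 224000 nM
compound 2 `CCCCCn1c(C)cc(NCc2ccccc2)cc1=O` — > 300000 nM, a limit of the assay, not a number

Going by the values given here, in a functional assay on K562 cells (Homo sapiens) for inhibition, read by MTT assay, with a stated time of 48 h (on this read-out higher numbers stand for weaker inhibition and lower numbers for stronger inhibition), compound 1 gives 224000 nM, the only number in the set. Compound 2 sits at the limit of > 300000 nM in this assay, at which 1 of the 2 values shown sits. Compound 3 `Cc1cc(NCCC(C)C)cc(=O)n1CCC(C)C` differs from compound 1 by isobutyl in place of 4-chlorophenyl on a saturated chain carbon bound to a nitrogen on an aromatic ring. Among the compounds with values here, no pair of measured compounds differs in one place, so no step is known. Compound 3 is expected to weaken slightly or stay within the scatter, with a fair chance of reaching the limit; the expected step is a 1.4-fold higher number from compound 1 to compound 3 (0.15 log units; within the scatter). Compound 3 is estimated at 320000 nM, between 120000 nM and 1000000 nM.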

Compound 3, half-maximal inhibitory concentration: 128000 nM
The estimate for compound 3 lay 2.5-fold (0.40 log units) above the measured number; the range from low to high includes it.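

In this assay, going by these compounds alone, isobutyl in place of 4-chlorophenyl on a saturated chain carbon bound to a nitrogen on an aromatic ring gives the first readable step at this position (a 1.8-fold lower number from compound 1 to compound 3 (0.24 log units; within the scatter)). The aromatic ring and its chlorine can therefore leave this position with no change beyond the scatter. A ring is not required here for activity at this level.

Going by these compounds, whether an amine or a carboxylic acid on this arm would move the number beyond the scatter stays open. Compound 2 differs from compound 1 in more than one place, and its value is a limit, not a number: the limit of > 300000 nM in this assay, at which 1 of the 3 values shown sits.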